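Methyl Added to the Ester and Thioester Alkyl Chain

This account rests on a few compounds, and the source may have more. Where it says the series, first, only, none or still open, it means among the compounds named here.

Measured compounds:
compound 1, `CCOC(=O)/C=C(C)/C=C/CC(C)CCCC(C)(C)O`: 4.65
compound 2, `CC(/C=C/CC(C)CCCC(C)(C)O)=C\C(=O)OC(C)C`: 5.06
compound 3, `CCSC(=O)/C=C(C)/C=C/CC(C)CCCC(C)C`: 7.98

Three compounds were measured in a physicochemical assay for lipophilicity; on this read-out higher numbers stand for higher lipophilicity and lower numbers for lower lipophilicity. Compound 2 differs from compound 1 by methyl in place of hydrogen on a saturated chain carbon bound to an oxygen next to a carbonyl group and a saturated chain carbon; this step reads a number 0.41 log units higher from compound 1 to compound 2 (beyond the scatter). Compound 3 stands highest of the three, with compound 2 nearest and compound 1 furthest; how its core differs from the core of compound 1 is not broken down here.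

Compound 4, `CC(/C=C/CC(C)CCCC(C)C)=C\C(=O)SC(C)C`, has not yet been measured in this assay. It differs from compound 3 by methyl in place of hydrogen on a saturated chain carbon bound to a saturated chain carbon and a sulfur. Going by the values given here, this is the same kind of change as the one from compound 1 to compound 2, but the surroundings differ: in the earlier pair the carbon that receives the methyl is bound to an oxygen next to a carbonyl group and a saturated chain carbon, whereas in compound 3 it is bound to a saturated chain carbon and a sulfur. Because the earlier step gave a number 0.41 log units higher from compound 1 to compound 2 (beyond the scatter), a step of similar size is expected here, namely a number 0.40 log units higher from compound 3 to compound 4 (beyond the scatter), with some allowance for the different neighbourhood of the place. Compound 4 is therefore expected to give 8.38 in this assay, within a range from 8 to 8.8.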

Compound 4, partition coefficient: 8.39
Compound 4: the middle estimate sits 0.01 log units below what was measured; low and high end bracket the measured number.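

In this assay the change from ethyl to isopropyl gave a number 0.41 log units higher from compound 3 to compound 4 (beyond the scatter), a step of the same printed size as the earlier one, a number 0.41 log units higher from compound 1 to compound 2 (beyond the scatter), so in these two pairs the added methyl carried over from the ester on the core of compound 1 to the thioester on the core of compound 3 without a change in the size of its step. Going by these compounds alone, this rests on only two pairs, whose cores differ both in the oxygen or sulfur that holds the chain and elsewhere, so the match does not show which of these differences matters, if any, and does not show that the step would hold on a further core. No measurement shown here offers an explanation for the agreement between the two steps.

The compounds shown carry only ethyl and isopropyl in this place, so it remains open whether a tert-butyl group or a longer chain such as butyl would extend the step, and what an amine or a carboxylic acid on that chain would do. On these data alone, it also remains open whether the two cores would keep their steps in step with each other for any of these groups.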